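Replacing the 1,3-thiazol-5-yl group of compound 2

The compounds below may be only part of what the source reports. "The series", "measured", "known", "first", "only" and "open" are said of these compounds alone.

Compound 1 `CCCCCCCCCCCC[C@@H](O)[C@H]1CC[C@H]([C@H](O)CCCCCCCCCCNC(=O)c2ccoc2)O1`: 74100 nM
Compound 2 `CCCCCCCCCCCC[C@@H](O)[C@H]1CC[C@H]([C@H](O)CCCCCCCCCCNC(=O)c2cncs2)O1`: 100000 nM

Within the data shown here, in a functional assay on OVCAR-4 cells (Homo sapiens) for inhibition, read by colorimetric assay and sulforhodamine B assay, with a stated time of 48 h (on this read-out lower numbers stand for stronger inhibition of growth and higher numbers for weaker inhibition of growth), compound 2 gives 100000 nM, level with the only other measured compound. Compound 3 `CCCCCCCCCCCC[C@@H](O)[C@H]1CC[C@H]([C@H](O)CCCCCCCCCCNC(=O)c2ccnn2C)O1` carries 1-methyl-1H-pyrazol-5-yl in place of 1,3-thiazol-5-yl on a carbonyl carbon. Among the measured compounds shown here, one measured step bears on this change, an exchange of groups at the same place: a 1.3-fold higher number from compound 1 to compound 2 (0.13 log units; within the scatter). On that single step, no change beyond the scatter is expected. The expected step is a 1.3-fold lower number from compound 2 to compound 3 (0.10 log units; within the scatter). For compound 3 the estimate is 80000 nM, with an expected range from 35000 nM to 150000 nM.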

Compound 3, concentration for 50% growth inhibition: 22900 nM
Estimate against measurement, compound 3: 3.5-fold (0.54 log units) above, and the stated range ends above it.
By their numbers in this assay, from the lowest: compound 3; then compounds 1 and 2 (each within the scatter of the next).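

In this assay this place on a carbonyl carbon responds to the group it carries: 1-methyl-1H-pyrazol-5-yl gives a 4.4-fold lower number from compound 2 to compound 3 (0.64 log units; beyond the scatter) and also a 3.2-fold lower number from compound 1 to compound 3 (0.51 log units; beyond the scatter), whereas the exchange between furan-3-yl and 1,3-thiazol-5-yl had stayed within the scatter. The position is therefore not indifferent to the group, though both steps are modest in size. Nothing available accounts for this difference.

The compounds shown leave open whether the methyl on the pyrazole matters, as the same ring without that methyl does not appear among them. They also leave open how a carboxylic acid or an amine on this ring would read.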